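The compounds below may be only part of what the source reports. "The series", "measured", "known", "first", "only" and "open" are said of these compounds alone.

Working notes on the series. Compound 1 `Cc1ccc(CN2CCC(NC(=O)NCc3ccc(-c4ccc(F)cc4)cc3)CC2)cc1` carries the 4-fluorophenyl and an unsubstituted amide nitrogen; compound 2 `COc1ccccc1-c1ccc(CNC(=O)NC2CCN(Cc3ccc(C)cc3)CC2)cc1` carries the 2-methoxyphenyl instead; compound 3 `Cc1ccc(CN2CCC(NC(=O)N(CC(=O)C(C)(C)O)Cc3ccc(-c4ccc(F)cc4)cc3)CC2)cc1` keeps the 4-fluorophenyl but bears the ((1-hydroxy-1-methylethyl)carbonyl)methyl on the amide-type nitrogen; compound 4 `COc1ccccc1-c1ccc(CN(CC(=O)C(C)(C)O)C(=O)NC2CCN(Cc3ccc(C)cc3)CC2)cc1` combines the substituted nitrogen with the 2-methoxyphenyl. In an in vitro functional assay on HEK293 cells for antagonist activity at melanin-concentrating hormone receptor 1 (Homo sapiens) (a higher number here means a larger maximal response, a lower number a smaller maximal response), compound 1 gives 105%, compound 2 gives 99.5% and compound 3 gives 79%. Compound 3 therefore stands lowest of the three numbers in this assay, with compound 2 nearest and compound 1 furthest, both beyond the scatter. Two measured steps exist. The ring swap alone gave a number 5.5 percentage points lower from compound 1 to compound 2 (within the scatter). The substitution on the nitrogen alone gave a number 26 percentage points lower from compound 1 to compound 3 (beyond the scatter). The change from compound 3 to compound 4 is 2-methoxyphenyl in place of 4-fluorophenyl on an aromatic carbon, that is, the same ring swap applied to the nitrogen-substituted compound. Within the data shown here, only the step from compound 1 to compound 2 bears on it, and it lay within the scatter, so for compound 4 no step beyond the scatter is expected; the estimate corresponds to a number 5 percentage points lower from compound 3 to compound 4 (within the scatter). Compound 4 is expected to reach 74% in this assay, with a range from 58% to 90%.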

Compound 4, largest response reached (reported as Imax), in percent of the reference or control that the assay uses: 68.3%
Estimate against measurement, compound 4: 5.7 percentage points above; measured number inside the range.
By their numbers in this assay, from the lowest: compound 4; then compound 3; then compounds 2 and 1 (each within the scatter of the next).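

In this assay the 2-methoxyphenyl in place of 4-fluorophenyl gives a number 10.7 percentage points lower from compound 3 to compound 4 (beyond the scatter) on the nitrogen-substituted core, so the ring swap now produces a step beyond the scatter, yet its size agrees with that on the unsubstituted core: the same change on two cores in this assay, a number 5.5 percentage points lower (within the scatter) from compound 1 to compound 2 and a number 10.7 percentage points lower (beyond the scatter) from compound 3 to compound 4, 5.2 percentage points apart, within the scatter of two such steps. The ((1-hydroxy-1-methylethyl)carbonyl)methyl on the amide-type nitrogen, now read on the 2-methoxyphenyl core as well, gives a number 31.2 percentage points lower from compound 2 to compound 4 (beyond the scatter) and so lowers the number on both cores by a matching amount: the same change on two cores in this assay, a number 26 percentage points lower (beyond the scatter) from compound 1 to compound 3 and a number 31.2 percentage points lower (beyond the scatter) from compound 2 to compound 4, 5.2 percentage points apart, within the scatter of two such steps. Across these four compounds the two changes therefore behave as independent of each other, and compound 4, which carries both, has the lowest number.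

It remains open whether the lower maximal response depends on the hydroxyl, the carbonyl or the chain as a whole, since a single substituent on the nitrogen is shown, and an amine, a carboxylic acid or a longer chain there could separate these. Whether the independence of the two changes extends to other groups in place of the 4-fluorophenyl, such as a nitrile-bearing phenyl, also stays unanswered.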